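Chloro on the carbamoyl ring of compound 2

This account rests on a few compounds, and the source may have more. Where it says the series, first, only, none or still open, it means among the compounds named here.

Measured so far in a functional assay on K562 cells (Homo sapiens) for inhibition, read by trypan blue exclusion, with a stated time of 24 h, tested at 10 uM; a lower number here means less inhibition of growth, a higher number more inhibition of growth at the concentration tested:
compound 1 `Cc1ccccc1OCC(=O)Nc1ccccc1C(N)=O` gives 19.7%
compound 2 `Cc1ccc(OCC(=O)Nc2ccccc2C(N)=O)cc1` gives < 10% as a limit
compound 3 `NC(=O)c1ccccc1NC(=O)COc1cccc(Cl)c1Cl` gives < 10% as a limit

Compound 2 gives < 10% as a limit and not a number, and it thus stands at the limit of < 10% in this assay, at which 2 of the 3 values shown sit, without a defined value of its own. The next structure is compound 4 `Cc1ccc(OCC(=O)Nc2ccc(Cl)cc2C(N)=O)cc1` with the change chloro in place of hydrogen on an aromatic carbon as its only difference: chloro in place of hydrogen on an aromatic carbon, meta to a carbamoyl group and para to a large group.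

Among the measured compounds shown here, no measured step makes this change. For the measured compounds named here, the one measured step is a number at least 9.7 percentage points lower from compound 1 to compound 2 (that floor lies within the scatter) with 4-methylphenyl in place of 2-methylphenyl, and it concerns another place in the molecule. It therefore gives no direct measure for chloro here. Compound 3 also holds chlorine, in another place, and gives < 10% as a limit.

With so little to go on, no step beyond the scatter is expected, and a small rise is the most that can be suggested. The estimated change is a number at least 1 percentage points higher from compound 2 to compound 4 (that floor lies within the scatter) on this reading. For compound 4 the expected value is 11% with an estimated range from 3% to 30% in this assay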

Compound 4, percent growth inhibition at one concentration: 24.1%
Compound 4: middle estimate off by 13.1 percentage points, on the low side; the measured number falls inside the stated range.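

In this assay, chloro in place of hydrogen on an aromatic carbon, meta to a carbamoyl group and para to a large group, gives a number at least 14.1 percentage points higher from compound 2 to compound 4 (beyond the scatter). This is the only step shown that lies beyond the scatter, so the carbamoyl-bearing ring is a place where a single chlorine can move the read-out, something the step between 2-methylphenyl and 4-methylphenyl could not establish. The true size of the step remains unknown and only its floor can be stated, because compound 2 has a limit and not a number: the limit of < 10% in this assay, at which 2 of the 4 values shown sit.

Going by these compounds, it remains open whether the rise belongs to chloro specifically or would also appear with fluoro, methyl, methoxy, an amine or a carboxylic acid at this position. On these data alone, it is equally open whether the same chloro change would produce a comparable step on the core of compound 1, which carries 2-methylphenyl in place of 4-methylphenyl.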